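The compounds below may be only part of what the source reports. "The series", "measured", "known", "first", "only" and "open" are said of these compounds alone.

Measured so far:
compound 1 `CNC(=O)c1cc(Oc2ccc3nc(NC(=O)c4cccc(F)n4)sc3c2)ccn1`, in a functional assay on SK-BR-3 cells (Homo sapiens) for inhibition, read by MTT assay, with a stated time of 2 days, tested at 10 uM (on this read-out lower numbers stand for less inhibition of growth and higher numbers for more inhibition of growth at the one concentration tested), compound 1 gives 12.5%;
compound 2 `CNC(=O)c1cc(Oc2ccc3nc(NC(=O)Nc4ccc(Br)cc4)sc3c2)ccn1`, in this assay compound 2 gives 26.7%.

For the measured compounds named here, on these two numbers compound 2 stands highest, and the only step seen, a number 14.2 percentage points higher from compound 1 to compound 2 (beyond the scatter), changed a different part of the molecule. Compound 3 `CNC(=O)c1cc(Oc2ccc3nc(NC(=O)Nc4ccc(Cl)cc4Cl)sc3c2)ccn1` differs from compound 2 only in 2,4-dichlorophenyl in place of 4-bromophenyl on an amide-type nitrogen. Going by the values given here, no measured step touches this ring, so there is nothing to point in either direction; a change within the scatter is expected, estimated as a number 1.3 percentage points higher from compound 2 to compound 3 (within the scatter). Compound 3 is therefore expected to give about 28%, between 12% and 45%.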

Compound 3, percent growth inhibition at one concentration: 22.3%
The estimate for compound 3 lay 5.7 percentage points above the measured number, and the stated range covers the measured number.
By their numbers in this assay, from the lowest: compounds 1, 3 and 2 (each within the scatter of the next, the first and the last beyond it).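

In this assay, exchanging the ring on the amide-type nitrogen gives a number 4.4 percentage points lower from compound 2 to compound 3 (within the scatter) and so does not separate 2,4-dichlorophenyl from 4-bromophenyl. The wider change gives a number 9.8 percentage points higher from compound 1 to compound 3 (within the scatter) and so does not repeat the step beyond the scatter seen with compound 2, which makes that earlier step less general. No measurement shown gives a reason for these numbers. Still open, going by these compounds, is how this nitrogen behaves with something other than a halogen-bearing phenyl ring, such as a plain methyl, a longer alkyl chain, or a phenyl ring carrying a carboxylic acid.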